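From 4-methylphenyl to 4-methoxyphenyl in the series

The compounds below may be only part of what the source reports. "The series", "measured", "known", "first", "only" and "open" are said of these compounds alone.

Compound 2 (`Cc1ccc(N2C(=O)COc3ccc(-c4cnc5ccccc5c4)cc32)cc1`) gives > 40000 nM in a functional assay on A-375 cells (Homo sapiens) for antiproliferative activity, read by MTT assay, with a stated time of 72 h (on this read-out higher numbers stand for weaker inhibition and lower numbers for stronger inhibition), and this value is a limit of the assay, not a number. Going by the values given here, compound 1 (`COc1cccc(N2C(=O)COc3ccc(-c4cnc5ccccc5c4)cc32)c1`) gives 23600 nM in this assay as the only numeric value so far. The change to compound 3 (`COc1ccc(N2C(=O)COc3ccc(-c4cnc5ccccc5c4)cc32)cc1`) is methoxy in place of methyl on an aromatic carbon with methoxy in place of methyl on an aromatic carbon, para to a large group, so that 4-methylphenyl becomes 4-methoxyphenyl. Among the compounds with values here, one measured step bears on this, namely an at least 1.6-fold higher number from compound 1 to compound 2 (0.22 log units; that floor lies within the scatter) and it alters both the group and its place on the ring, so it does not isolate the methoxy for methyl swap. Compound 3 shares a methoxy with compound 1 at 23600 nM but in another place. In this assay a small move toward lower numbers is therefore expected, possibly none beyond the scatter. The expected change is an at least 1.4-fold lower number from compound 2 to compound 3 (0.15 log units; that floor lies within the scatter) as an estimate resting on a single pair. For compound 3 the expected value is 28000 nM within an estimated range of 12000 nM to 55000 nM and a report of only a limit remains quite possible.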

Compound 3, half-maximal inhibitory concentration: > 40000 nM
Compound 3: only a limit was reported; the forecaster's own chance of this, stated with the estimate: 40%; middle value at least 1.4-fold (0.15 log units) away from the limit.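

In this assay compound 3 gives > 40000 nM, which is a limit of the assay and not a number. The effect of methoxy in place of methyl at this position therefore cannot be read, and no size can be given for that step, because compound 2 and compound 3 both sit at the same limit: the limit of > 40000 nM in this assay, at which 2 of the 3 values shown sit.

The new information comes from holding the methoxy group constant and changing only its place on the ring, which gives an at least 1.6-fold higher number from compound 1 to compound 3 (0.22 log units; that floor lies within the scatter); that floor lies within the scatter, so the comparison shows no clear separation between 3-methoxyphenyl and 4-methoxyphenyl, though it also rules none out.

The compounds shown leave open how far compound 2 and compound 3 lie past the limit, and whether the two differ from each other at all. They also leave open whether an amine or a carboxylic acid on the same aromatic carbon would give a numeric value in this assay, and so whether this position can carry any measurable antiproliferative activity on the shared core.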